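The source may hold more compounds than are shown below. What is called first, only, known or untested is meant among the compounds shown, and "the series" means these compounds.

Within the data shown here, in a functional assay on U-87MG ATCC cells for antiproliferative activity against U-87 MG (Homo sapiens), with a stated time of 5 days (on this read-out lower numbers stand for an effect already at smaller amounts and higher numbers for an effect only at larger amounts of compound), compound 2 (`Nc1nc2cc(-c3nn(CC4CCCC4)c4ncnc(N)c34)ccc2o1`) gives 13 nM, the lowest of the two numbers so far, while compound 1 (`Nc1nc2cc(-c3nn(C[C@H]4CCCO4)c4ncnc(N)c34)ccc2o1`) gives 100 nM. Compound 3 (`Nc1nc2cc(-c3nn(C[C@@H]4CCCO4)c4ncnc(N)c34)ccc2o1`) follows from compound 2 with oxolan-2-yl in place of cyclopentyl on a saturated chain carbon bound to an aromatic nitrogen. Among the measured compounds shown here, the one measured step that bears on this is the reverse exchange, a 7.7-fold lower number from compound 1 to compound 2 (0.89 log units; beyond the scatter), which lies beyond the scatter. For the measured compounds named here, compound 1 carries the same group with the opposite configuration at its defined stereocentre, and no measurement yet shows how much that configuration matters in this assay. A step of similar size towards a higher number is therefore expected, and the estimated step is a 6.9-fold higher number from compound 2 to compound 3 (0.84 log units; beyond the scatter). For compound 3 the estimated value is 90 nM, with an expected range of 25 nM to 350 nM.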

Compound 3, half-maximal effective concentration: 100 nM
The estimate for compound 3 lay 1.1-fold (0.05 log units) below the measured number, and the stated range covers the measured number.
By their numbers in this assay, from the lowest: compound 2; then compounds 1 and 3 (each within the scatter of the next).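

In this assay, oxolan-2-yl in place of cyclopentyl on a saturated chain carbon bound to an aromatic nitrogen gives a 7.7-fold higher number from compound 2 to compound 3 (0.89 log units; beyond the scatter), so this exchange now holds for both drawn forms of the group. The earlier compounds shown here could not show whether configuration at the saturated ring carbon matters, and the new pair gives no change at the digits printed from compound 1 to compound 3 (within the scatter). The gap to compound 2 therefore follows the exchange of cyclopentyl for oxolan-2-yl and not the drawn configuration, a reading that rests on this: the fact that compounds 1 and 3 differ only in the configuration as drawn.

The compounds shown do not tell why the exchange raises the number in this assay. They also leave open where a cyclohexyl group or a pyrrolidine amine at this place would fall relative to compound 2 and compound 3.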